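The source may hold more compounds than are shown below. What is called first, only, known or untested is meant among the compounds shown, and "the series" means these compounds.

In a functional assay on HeLa cells (Homo sapiens) for inhibition (a lower number here means a stronger inhibitor, a higher number a weaker inhibitor), compound 1 `O=C/C=C/n1cc(CO)c(=O)[nH]c1=O` gives > 100000 nM, which is a limit of the assay and not a number. Going by the values given here, compound 2 `O=C/C=C/n1c(=O)ccn([C@H]2C[C@H](O)[C@@H](CO)O2)c1=O` gives 800 nM and compound 3 `CC(=O)/C=C/n1c(=O)ccn([C@H]2C[C@H](O)[C@@H](CO)O2)c1=O` gives 1500 nM, so compound 3 stands within the scatter of the only other true number. Compound 4 `N#C/C=C/n1c(=O)ccn([C@H]2C[C@H](O)[C@@H](CO)O2)c1=O` differs from compound 3 in one place: cyano in place of acetyl on a double-bonded chain carbon bound to a double-bonded chain carbon. The change is cyano in place of acetyl on a double-bonded chain carbon bound to a double-bonded chain carbon. Among the compounds with values here, the one measured step at this end of the chain, a 1.9-fold higher number from compound 2 to compound 3 (0.27 log units; within the scatter), stayed within the scatter, so no step beyond the scatter is expected in this assay. The expected step is a 1.3-fold higher number from compound 3 to compound 4 (0.12 log units; within the scatter). The value estimated for compound 4 is 2000 nM, with an expected range from 500 nM to 8000 nM.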

Compound 4, half-maximal inhibitory concentration: 100000 nM
Compound 4: middle estimate off by 50-fold (1.70 log units), on the low side; the measured number lies above the stated range.
By their numbers in this assay, from the lowest: compounds 2 and 3 (each within the scatter of the next); then compound 4.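

In this assay, cyano in place of acetyl on this double-bonded chain carbon gives a 67-fold higher number from compound 3 to compound 4 (1.82 log units; beyond the scatter), and cyano in place of formyl gives a 130-fold higher number from compound 2 to compound 4 (2.10 log units; beyond the scatter). Going by these compounds alone, the earlier step between formyl and acetyl stayed within the scatter, so only this change shows that the group at this position can move the number by a large step. Compound 4 reads the same figure as the limit held by compound 1: the limit of > 100000 nM in this assay, at which 1 of the 4 values shown sits.

On these data alone, it remains open whether a carboxylic acid or an amide on this carbon would read like compound 2 and compound 3 or like compound 4.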